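Swapping hexylamino for hydroxy at a growth-inhibition limit

This account rests on a few compounds, and the source may have more. Where it says the series, first, only, none or still open, it means among the compounds named here.

Of the compounds shown here, three with a hexylamino group have been tested so far in a functional assay on SN12C cells (Homo sapiens) for antiproliferative activity (a higher number here means a weaker inhibitor of growth, a lower number a stronger inhibitor of growth), on these cells. Compound 1 `CCCCCCNC(=O)c1cc(CCc2cc(O)ccc2O)ccc1O` gives 2200 nM there, and compound 3 `CCCCCCNC(=O)c1cc(/C=C\c2cc(O)ccc2O)ccc1O` gives 11600 nM there too.

Compound 2 `CCCCCCNC(=O)c1cc(C#Cc2cc(OC)ccc2OC)ccc1OC` returns > 100000 nM as its result, which is a limit and not a number.

Compound 4 `COc1ccc(OC)c(C#Cc2ccc(OC)c(C(=O)O)c2)c1` keeps the rest of compound 2 and makes one change, hydroxy in place of hexylamino on a carbonyl carbon, so that hexylcarbamoyl becomes carboxy. Among the measured compounds shown here, no pair of tested compounds shows this change, so this assay offers no direct guide to its size.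

The expectation therefore starts from compound 2 alone, with its limit of > 100000 nM as the only anchor. The expected step is a number no higher from compound 2 to compound 4 (the limit leaves the size open) in size, which means no change beyond the scatter in either direction. Compound 4 may well return a limit too. If a number appears, compound 4 is estimated at 100000 nM (expected range 30000 nM to 300000 nM).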

Compound 4, concentration for 50% growth inhibition: 38200 nM
Compound 4: the middle estimate sits 2.6-fold (0.42 log units) above what was measured; the measured number falls inside the stated range.
By their numbers in this assay, from the lowest: compound 1; then compound 3; then compound 4. At a limit, above all of these: compound 2.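

Until now every compound carried hexylamino on this carbonyl carbon, so nothing showed whether this position matters for growth inhibition. In this assay, among the compounds shown here, changing hexylcarbamoyl to carboxy gives an at least 2.6-fold lower number from compound 2 to compound 4 (0.41 log units; beyond the scatter), the first sign that the group on this carbon can shift the read-out and that hexylamino is not required for a measurable value on this core. Compound 2 stands at a limit, so this step has a known minimum but no known full size: the limit of > 100000 nM in this assay, at which 1 of the 4 values shown sits.

From the compounds shown here alone, whether a methyl ester, a primary amide or a shorter chain such as butylamino would give a lower or higher number at this carbon remains open. Going by these compounds, it is also open whether the same swap would act in the same direction on the cores of compound 1 and compound 3.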